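The source may report more compounds than this note shows. Statements on the series, on what has been measured and on what is new or still open speak of the compounds shown alone.

Among the measured compounds shown here, compound 2 `COc1cccc(C(=O)O[C@@H]2CO[C@H]3[C@@H]2OC[C@@H]3OC(=O)c2ccccc2OC(C)=O)c1` gives 0.0142 h in an ADME assay on a cell-free system (plasma, Homo sapiens) for metabolic stability, with Plasma (Rattus norvegicus) as the target, read by HPLC, at pH 7.4 (a higher number here means that the compound lasts longer, a lower number that the compound disappears faster), the lowest of the two numbers so far. Compound 1 `CC(=O)Oc1ccccc1C(=O)O[C@H]1CO[C@H]2[C@@H]1OC[C@H]2OC(=O)c1ccccc1O` gives 0.019 h, and the move a 1.3-fold lower number from compound 1 to compound 2 (0.13 log units; within the scatter) separates them, which is within the scatter. Compound 3 `COc1ccc(C(=O)O[C@@H]2CO[C@H]3[C@@H]2OC[C@@H]3OC(=O)c2ccccc2OC(C)=O)cc1` carries 4-methoxyphenyl in place of 3-methoxyphenyl on a carbonyl carbon. For the measured compounds named here, no measured step exchanges one methoxyphenyl for another; the only change at this carbonyl carbon, a 1.3-fold lower number from compound 1 to compound 2 (0.13 log units; within the scatter), stayed within the scatter, so no step beyond the scatter is expected in this assay. Compound 3 is estimated at 0.015 h, with a range from 0.007 h to 0.032 h, meaning an expected step of a 1.1-fold higher number from compound 2 to compound 3 (0.02 log units; within the scatter).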

Compound 3, half-life: 0.0183 h
Compound 3: the middle estimate sits 1.2-fold (0.09 log units) below what was measured; the measured number falls inside the stated range.
By their numbers in this assay, from the lowest: compounds 2, 3 and 1 (each within the scatter of the next).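

At the carbonyl carbon whose other neighbour is oxygen next to a carbonyl group, 4-methoxyphenyl in place of 3-methoxyphenyl gives a 1.3-fold higher number from compound 2 to compound 3 (0.11 log units; within the scatter) in this assay and 4-methoxyphenyl in place of 2-hydroxyphenyl gives a 1.0-fold lower number from compound 1 to compound 3 (0.02 log units; within the scatter) at the same place. All three groups at this position therefore stand within the scatter of one another, including the two methoxyphenyl isomers. No evidence at hand bears on this result.

Still open, as far as these compounds go, is whether any group here gives a step beyond the scatter, such as an aminophenyl, a carboxylic acid-bearing phenyl or a longer alkyl chain.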